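The compounds below may be only part of what the source reports. "The series", "measured", "known", "first", "only" and "open" are said of these compounds alone.

In a functional assay on HepG2 cells (Homo sapiens) for antiproliferative activity, read by MTT assay, with a stated time of 48 h (a lower number here means a stronger inhibitor, a higher number a weaker inhibitor), compound 1 `O=C(/C=C/c1ccc(/C=C/C(=O)c2ccc3ccccc3c2)o1)NO` gives 9930 nM and compound 2 `O=C(CCCCCCC(=O)Nc1ccccc1C(=O)NO)Nc1ccccc1` gives 63500 nM as its result, so compound 1 holds the lower, stronger number of the two, with a gap beyond the usual scatter. Compound 3 `COc1ccc2cc(C(=O)/C=C/c3ccc(/C=C/C(=O)NO)o3)ccc2c1` differs from compound 1 in one place, with methoxy in place of hydrogen on an aromatic carbon of the core. Among the measured compounds shown here, no measured pair shows this change. The expected step is a 1.4-fold lower number from compound 1 to compound 3 (0.15 log units; within the scatter) in this assay and is small, slightly toward a stronger number, and probably not beyond the scatter. For compound 3 the estimated value is 7000 nM with an expected range from 2500 nM to 20000 nM on measurement.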

Compound 3, half-maximal inhibitory concentration: 6220 nM
Compound 3: middle estimate off by 1.1-fold (0.05 log units), on the high side; the measured number falls inside the stated range.
By their numbers in this assay, from the lowest: compounds 3 and 1 (each within the scatter of the next); then compound 2.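

In this assay, methoxy in place of hydrogen on an aromatic carbon gives a 1.6-fold lower number from compound 1 to compound 3 (0.20 log units; within the scatter), so this position of the core accepts a group of 2 heavy atoms with no change beyond the scatter. Among the compounds shown here, this is the first reading at this position, and it shows that methoxy here neither clearly helps nor clearly harms. No measured evidence here explains this result. Still open, going by these compounds, is whether an amine, a carboxylic acid or a longer alkoxy chain on this same carbon would shift the number beyond the scatter. Also open, on these data alone, is how methoxy would behave on other carbons of this ring.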